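Chloro for methyl on the aryl group of compound 2

A few compounds are considered here, and "the series" means these few. Any claim that something is new, unique, unknown or untested is made for them only; others in the source may bear on it.

Working notes on the series. Compound 2 `Cc1cccc(-c2noc(C3CN(C(=O)c4ccccc4F)C3)n2)c1` carries a 3-methylphenyl group and a fluorobenzoyl amide on the shared core. In an assay on HEK293 cells for positive allosteric modulation of metabotropic glutamate receptor 5 (Homo sapiens), read by FLIPR (a lower number here means that less compound is needed, a higher number that more compound is needed for the effect), compound 2 reaches only the assay limit of > 10000 nM, which is a limit and not a number. Compound 2 thus sits at the limit of > 10000 nM in this assay, at which 1 of the 2 values shown sits. Compound 1 `O=C(N1CCCCC1)N1CC(c2nc(-c3cccc(Cl)c3)no2)C1`, with a 3-chlorophenyl group and a piperidine urea on the same core, gives 370 nM in this assay. Compound 3 `O=C(c1ccccc1F)N1CC(c2nc(-c3cccc(Cl)c3)no2)C1` differs from compound 2 by chloro in place of methyl on an aromatic carbon; it keeps the fluorobenzoyl amide of compound 2 and takes the 3-chlorophenyl group of compound 1. Among the compounds with values here, no measured pair isolates this swap. The step from compound 2 to compound 3 is expected to run toward less compound needed, an at least 2.0-fold lower number from compound 2 to compound 3 (0.30 log units; that floor lies within the scatter), though its size is uncertain. Given that compound 1 gives 370 nM with the chloro group in place, compound 3 is estimated at 5000 nM, between 1000 nM and 20000 nM. A limit-only result remains possible.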

Compound 3, half-maximal effective concentration: > 10000 nM
Compound 3: no number, only a limit; the forecaster's own chance of this, stated with the estimate: 45%; middle value at least 2.0-fold (0.30 log units) from the limit.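

With the 2-fluorophenyl group on the carbonyl carbon, the 3-chlorophenyl group does not give a measurable value in this assay. Compound 2 and compound 3 both rest on limits, so the step between them cannot be read and any effect of chloro in place of methyl stays hidden: the limit of > 10000 nM in this assay, at which 2 of the 3 values shown sit.

The change at the other place is readable and large, an at least 27-fold higher number from compound 1 to compound 3 (1.43 log units; beyond the scatter), so in this pair the measurable value stands with the piperidin-1-yl group and not with the chloro group alone.

From the compounds shown here alone, whether chloro or methyl gives the lower number remains open; a 3-methylphenyl group paired with the piperidine urea would read that swap directly. Also open, going by these compounds, is how much of the piperidin-1-yl group is needed, for instance whether a morpholine or a dimethylamino group on the carbonyl carbon keeps a measurable value.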